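Phenyl in place of benzyl on compound 3

The compounds below may be only part of what the source reports. "The series", "measured", "known", "first", "only" and "open" are said of these compounds alone.

In a functional assay on DU-145 cells (Homo sapiens) for cytotoxicity, read by MTT assay (on this read-out lower numbers stand for stronger inhibition and higher numbers for weaker inhibition), compound 1 (`CC(C)C[C@H](NC(=S)NCc1ccccc1)c1nc2ccccc2[nH]1`) gives 21100 nM, compound 2 (`CC(C)C[C@H](NC(=S)Nc1ccccc1)c1nc2ccccc2[nH]1`) gives 28900 nM and compound 3 (`C[C@H](NC(=S)NCc1ccccc1)c1nc2ccccc2[nH]1`) gives 226000 nM. Compound 3 thus holds the highest number of the three. Compound 2 stands nearer to it than compound 1, though the gap is beyond the scatter on either side.

The next entry is compound 4 (`C[C@H](NC(=S)Nc1ccccc1)c1nc2ccccc2[nH]1`), not yet measured in this assay. Its difference from compound 3 is phenyl in place of benzyl on an amide-type nitrogen, with the exchange sitting on an amide-type nitrogen.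

Among the compounds with values here, only one measured step makes the same exchange: a 1.4-fold higher number from compound 1 to compound 2 (0.14 log units; within the scatter). Within the data shown here, that step lies within the scatter, but it was measured on the pair that keeps the isopropyl group, and no pair without the isopropyl group has been measured. The other step, an 11-fold higher number from compound 1 to compound 3 (1.03 log units; beyond the scatter), is large, but it concerns the chain carbon and leaves the benzyl group untouched. It adds nothing to the exchange itself.

No step beyond the scatter is therefore expected, and the estimate means a 1.2-fold higher number from compound 3 to compound 4 (0.09 log units; within the scatter). For compound 4 the expected value is 280000 nM, with an estimated range from 130000 nM to 600000 nM.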

Compound 4, half-maximal inhibitory concentration: "not active" (no number reported)
Compound 4 has no reported number here, so the estimate cannot be set against anything.
By their numbers in this assay, from the lowest: compounds 1 and 2 (each within the scatter of the next); then compound 3.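

Within the data shown here, compound 4 is reported as "not active" without a number in this assay, so no step from compound 3 to compound 4 can be read. No evidence on hand bears on this result. The compounds shown leave open how far phenyl in place of benzyl shifts the number when the isopropyl group is absent.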